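Methyl to Ethyl on the Sulfur-Bound Chain: An Expectation

A few compounds are considered here, and "the series" means these few. Any claim that something is new, unique, unknown or untested is made for them only; others in the source may bear on it.

Measured compounds:
compound 1, `CSc1nnc(Cc2ccccc2Oc2ccccc2)[nH]1`, 133%
compound 2, `CCSc1nnc(Cc2ccccc2Oc2ccccc2)[nH]1`, 142%
compound 3, `CSc1nnc(Cc2ccc(Cl)cc2Oc2ccccc2F)[nH]1`, 121%

In a functional assay on the whole organism (strain NMRI) with Mus musculus as the target, with a stated time of 60 min, at a dose of 10 mg/kg by the intraperitoneal route (a lower number here means a weaker effect, a higher number a stronger effect of the compound at the dose given), compound 1 gives 133% and compound 2 gives 142%. The two differ by methyl in place of hydrogen on a saturated chain carbon bound to a sulfur, and the step of a number 9 percentage points higher from compound 1 to compound 2 (within the scatter). Compound 3, in this assay, gives 121%; the difference between its core and the core of compound 1 is not broken down here, and compound 3 stands lowest of the three measured numbers.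

Compound 4, `CCSc1nnc(Cc2ccc(Cl)cc2Oc2ccccc2F)[nH]1`, is not yet measured. It differs from compound 3 by methyl in place of hydrogen on a saturated chain carbon bound to a sulfur, the same kind of change as that from compound 1 to compound 2, made here on the core of compound 3.

On this single earlier step, which stayed within the scatter, the step from compound 3 to compound 4 is expected to be a number 7 percentage points higher from compound 3 to compound 4 (within the scatter) in this assay, small as the earlier one, because a number 9 percentage points higher from compound 1 to compound 2 (within the scatter). The estimate for compound 4 in this assay is 128%, expected to lie between 112% and 146%.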

Compound 4, a percentage reported as activity, at one dose (the size of the read-out at that dose, not a potency): 144%
Beside the measured number, compound 4's estimate is 16 percentage points below it; low and high end bracket the measured number.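

In this assay, the change from methylsulfanyl to ethylsulfanyl on the core of compound 3 gives a number 23 percentage points higher from compound 3 to compound 4 (beyond the scatter), and set beside the earlier step on the core of compound 1, the two steps cannot be told apart: the same change on two cores in this assay, a number 9 percentage points higher (within the scatter) from compound 1 to compound 2 and a number 23 percentage points higher (beyond the scatter) from compound 3 to compound 4, 14 percentage points apart, within the scatter of two such steps

The compounds shown therefore give no sign that the size of this step depends on the core. Going by these compounds alone, they do not establish that the step is constant, however: only two cores are at hand, at one dose in one assay, and only on the core of compound 3 does the step itself lie beyond the scatter.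

Open, on these data alone, is whether a longer chain on the sulfur, such as propyl, or a branched one, such as isopropyl, would behave in the same way on either core. Also open, as far as these compounds go, is what an amine or a carboxylic acid at the end of that chain would do to the read-out.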